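Halogen exchange on the shared core: from compound 1 to compound 4

The source may report more compounds than this note shows. Statements on the series, on what has been measured and on what is new or still open speak of the compounds shown alone.

- compound 1 `Cc1cc(-c2nc3c(F)cccc3s2)ccc1N`: 20900 nM
- compound 2 `Nc1ccc(-c2nc3cc(F)ccc3s2)cc1Cl`: 320 nM
- compound 3 `Nc1ccc(-c2nc3cc(F)ccc3s2)cc1Br`: 24000 nM

All three values come from a functional assay on OVCAR-4 cells (Homo sapiens) for inhibition; on this read-out lower numbers stand for stronger inhibition of growth and higher numbers for weaker inhibition of growth. Compound 1 and compound 3 lie within the scatter of each other, while the value of compound 2 is much lower than either.

The next compound to be read is compound 4 `Cc1cc(-c2nc3ccccc3s2)ccc1N`. Its structural difference from compound 1 is hydrogen in place of fluoro on an aromatic carbon. All three measured compounds carry a fluoro group, so no direct comparison for this exchange exists.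

Within the data shown here, the one measured step, a 75-fold higher number from compound 2 to compound 3 (1.88 log units; beyond the scatter), bears on it only indirectly. It is a large step for bromo in place of chloro on an aromatic carbon, so a single-atom exchange in this series can move the number far. That step is a different exchange and fixes no direction. Since compound 2 reaches 320 nM, a lower number is expected in this assay, though with little certainty.

The estimated step is a 21-fold lower number from compound 1 to compound 4 (1.32 log units; beyond the scatter).

For compound 4 the expected value is 1000 nM, with an estimated range from 30 nM to 30000 nM.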

Compound 4, concentration for 50% growth inhibition: 1100 nM
For compound 4 the middle estimate is 1.1-fold (0.04 log units) below the measured one; measured number inside the range.
By their numbers in this assay, from the lowest: compound 2; then compound 4; then compounds 1 and 3 (each within the scatter of the next).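

In this assay, among these compounds, the first direct reading of this exchange is a 19-fold lower number from compound 1 to compound 4 (1.28 log units; beyond the scatter), so hydrogen in place of fluoro on this aromatic carbon, ortho to a fused ring and meta to a fused ring, is a large change and not a silent one. The direction is now fixed for this one pair: compound 4, with hydrogen, stands at the lower number and so at the stronger inhibition of growth, while compound 1, with fluoro, stands at the weaker. Alongside a 75-fold higher number from compound 2 to compound 3 (1.88 log units; beyond the scatter), this makes a second single-atom exchange that moves the number far, although the two exchanges differ and their steps cannot be read as one trend. The compounds shown offer nothing that accounts for the size or direction of this step.

Going by these compounds, whether the step is tied to fluoro alone stays open, since one pair cannot say how chloro, methoxy or an amine on the same aromatic carbon would read. Also open, on these data alone, is whether the same exchange gives a step of like size and direction when chloro or bromo replaces methyl on the shared core.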